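Swapping Fluoro for Methoxy: Expected Effect on Cytotoxicity

The compounds below may be only part of what the source reports. "The series", "measured", "known", "first", "only" and "open" are said of these compounds alone.

Among the compounds with values here, compound 2 `Cc1c(Cc2ccccc2)c(=O)oc2cc(OCC(CN3CCC(C(N)=O)CC3)Oc3ccc(F)cc3)ccc12` is one of two compounds measured so far. In an ADME assay on A549 cells (Homo sapiens) for cytotoxicity, read by CellTiter-Glo (on this read-out lower numbers stand for higher toxicity in this test and higher numbers for lower toxicity in this test), compound 2 gives 66400 nM, and compound 1 `Cc1c(Cc2ccccc2)c(=O)oc2cc(OCC(CN3CCC(C(N)=O)CC3)Oc3ccccc3F)ccc12` gives 79600 nM, the two values lying within the scatter of each other. Within the data shown here, the single measured step, a 1.2-fold lower number from compound 1 to compound 2 (0.08 log units; within the scatter), stays within the scatter. Compound 3 `COc1ccc(OC(COc2ccc3c(C)c(Cc4ccccc4)c(=O)oc3c2)CN2CCC(C(N)=O)CC2)cc1` differs from compound 2 by methoxy in place of fluoro on an aromatic carbon. No measured step exchanges a fluoro for a methoxy, so nothing shown points to a shift beyond the scatter. Compound 3 is therefore expected to give about 66000 nM in this assay, with a range from 30000 nM to 150000 nM. The expected step is a 1.0-fold lower number from compound 2 to compound 3 (0.00 log units; within the scatter).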

Compound 3, half-maximal cytotoxic concentration: 94900 nM
For compound 3 the middle estimate is 1.4-fold (0.16 log units) below the measured one; low and high end bracket the measured number.
By their numbers in this assay, from the lowest: compounds 2, 1 and 3 (each within the scatter of the next).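

Within the data shown here, this is the first change of kind at this aromatic carbon, not just a move of the fluoro. In this assay the exchange of fluoro for methoxy gives a 1.4-fold higher number from compound 2 to compound 3 (0.16 log units; within the scatter) and the change from 2-fluorophenyl to 4-methoxyphenyl gives a 1.2-fold higher number from compound 1 to compound 3 (0.08 log units; within the scatter) and both steps stay within the scatter. Nothing available here speaks to why the read-out holds.

The compounds shown leave open whether an amine or a carboxylic acid on this carbon would shift the number beyond the scatter. Going by these compounds, whether a longer ether chain in place of methoxy would do so also stays open.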